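Solubility Across a Ring Swap on the Shared Core

The source may report more compounds than this note shows. Statements on the series, on what has been measured and on what is new or still open speak of the compounds shown alone.

Compound 1 `C=CC(=O)N1CCC[C@@H](N2C(=O)N(Cc3ccccc3)Cc3cnc(Nc4ccc(N5CCN(C)CC5)cc4OC)nc32)C1` gives 142 ug/mL in a physicochemical assay for solubility, read by HPLC, in phosphate buffer, measured as thermodynamic solubility, with a stated time of 24 h, at pH 6.8; on this read-out higher numbers stand for higher solubility and lower numbers for lower solubility.
Compound 2 `C=CC(=O)N1CCC[C@H](N2C(=O)N(Cc3ccccc3)Cc3cnc(Nc4ccc(N5CCN(C)CC5)cc4OC)nc32)C1` gives 129 ug/mL in this assay.

Compound 2 stands lowest of the two numbers in this assay, with compound 1 nearest to it. The step of a 1.1-fold lower number from compound 1 to compound 2 (0.04 log units; within the scatter) lies within the scatter, and the pair is accounted for by the fact that compounds 1 and 2 differ only in the configuration as drawn.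

Compound 3 `C=CC(=O)NC1CCC(N2C(=O)N(Cc3ccccc3)Cc3cnc(Nc4ccc(N5CCN(C)CC5)cc4OC)nc32)CC1` has not yet been measured. It differs from compound 2 in one place: 4-((vinylcarbonyl)amino)cyclohexyl in place of 1-(vinylcarbonyl)piperidin-3-yl on an amide-type nitrogen in a ring. Among the measured compounds shown here, the only measured step, a 1.1-fold lower number from compound 1 to compound 2 (0.04 log units; within the scatter), concerns configuration alone and leaves the exchanged group untouched, so no measured step speaks directly to this change in this assay. Compound 3 is therefore expected to land close to compound 2, with the step of a 1.3-fold lower number from compound 2 to compound 3 (0.11 log units; within the scatter) not expected to reach beyond the scatter. The estimate for compound 3 in this assay is 100 ug/mL, with a range from 35 ug/mL to 280 ug/mL.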

Compound 3, solubility: 18.8 ug/mL
Compound 3: the middle estimate sits 5.3-fold (0.73 log units) above what was measured, outside the stated range (below it).
By their numbers in this assay, from the lowest: compound 3; then compounds 2 and 1 (each within the scatter of the next).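

In this assay, among the compounds shown here, the earlier compounds showed only that configuration at this position leaves the number within the scatter; the group itself now proves to matter, as 4-((vinylcarbonyl)amino)cyclohexyl in place of 1-(vinylcarbonyl)piperidin-3-yl gives a 6.9-fold lower number from compound 2 to compound 3 (0.84 log units; beyond the scatter) and a 7.6-fold lower number from compound 1 to compound 3 (0.88 log units; beyond the scatter). Both steps lie beyond the scatter, so the result holds against either drawn configuration of the leaving group. The entering group has 1 hydrogen-bond donor and a ring of carbon only, where the leaving group has 0 hydrogen-bond donors and a ring with 1 hetero atom, but nothing shown explains the step.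

Which of these differences carries the step remains open. So does how a 1-(vinylcarbonyl)piperidin-4-yl group, or a cyclohexyl bearing a dimethylamino group, would read on this nitrogen.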